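The source may hold more compounds than are shown below. What is called first, only, known or untested is meant among the compounds shown, and "the series" means these compounds.

Compound 1 `CCC(=O)N(C)c1ccc2[nH]c(-c3n[nH]c4ccccc34)cc2n1` gives 6130 nM in a functional assay on HL-60 cells (Homo sapiens) for antiproliferative activity, read by MTT assay, with a stated time of 72 h; a higher number here means a weaker inhibitor, a lower number a stronger inhibitor.
Compound 2 `COc1ccc(C(=O)N(C)c2ccc3[nH]c(-c4n[nH]c5ccccc45)cc3n2)cc1` gives 3320 nM in this assay.

Compound 2 holds the lower of the two numbers, yet the step of a 1.8-fold lower number from compound 1 to compound 2 (0.27 log units; within the scatter) stays within the scatter, so the two compounds are not told apart. Compound 3 `COc1ccc(NC(=O)N(C)c2ccc3[nH]c(-c4n[nH]c5ccccc45)cc3n2)cc1` differs from compound 2 by (4-methoxyphenyl)amino in place of 4-methoxyphenyl on a carbonyl carbon. Among the measured compounds shown here, the one measured step also swapped the group on that carbonyl carbon and moved the number no more than the scatter allows; no measured step brings in an amino group. For compound 3 the expected change is therefore a 1.0-fold lower number from compound 2 to compound 3 (0.00 log units; within the scatter), none beyond the scatter. Compound 3 is estimated at 3300 nM, between 1500 nM and 7500 nM.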

Compound 3, half-maximal inhibitory concentration: 7.9 nM
Estimate against measurement, compound 3: 420-fold (2.62 log units) above; the whole stated range lies above it.
By their numbers in this assay, from the lowest: compound 3; then compounds 2 and 1 (each within the scatter of the next).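

The group on this carbonyl carbon can matter greatly in this assay, which the swap of ethyl for 4-methoxyphenyl did not reveal: placing an amino group between the carbonyl and the 4-methoxyphenyl ring gives a 420-fold lower number from compound 2 to compound 3 (2.62 log units; beyond the scatter). Measured against the ethyl group, (4-methoxyphenyl)amino gives a 780-fold lower number from compound 1 to compound 3 (2.89 log units; beyond the scatter). Nothing available explains this large change.

The compounds shown leave open whether the amino group alone suffices or needs the 4-methoxyphenyl ring. A plain phenylamino, a methylamino or a 4-methoxyphenoxy group on the same carbonyl carbon could separate these possibilities.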